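The source may hold more compounds than are shown below. What is called first, only, known or untested is meant among the compounds shown, and "the series" means these compounds.

Of the compounds shown here, three carry numbers so far. Compound 1 `O=C(Nc1ccc(Oc2ccnc3[nH]ccc23)cc1)c1cn(-c2ccc(Br)cc2F)c2ccccc2c1=O` gives 790 nM in a functional assay on HepG2 cells (Homo sapiens) for inhibition, read by MTT assay, with a stated time of 72 h; on this read-out lower numbers stand for stronger inhibition and higher numbers for weaker inhibition. Compound 2 `COc1ccc(-n2cc(C(=O)Nc3ccc(Oc4ccnc5[nH]ccc45)cc3)c(=O)c3ccccc32)cc1` gives 5950 nM in this assay, and compound 3 `Cn1ccc2c(Oc3ccc(NC(=O)c4cn(-c5ccccc5)c5ccccc5c4=O)cc3F)ccnc21` gives 2170 nM in this assay. Compound 3 thus stands second highest of the three, nearer to compound 2 and further from compound 1, both gaps beyond the scatter. For the measured compounds named here, the only step measured between compounds differing in one place is a 7.5-fold higher number from compound 1 to compound 2 (0.88 log units; beyond the scatter), in which a methoxy-bearing ring on the aromatic nitrogen replaced a halogen-bearing one and the number rose. Compound 4 `Cn1ccc2c(Oc3ccc(NC(=O)c4cn(-c5ccc(Cl)cc5)c5ccccc5c4=O)cc3F)ccnc21` differs from compound 3 by chloro in place of hydrogen on an aromatic carbon. Going by the values given here, no measured step adds a single chloro to an otherwise unsubstituted phenyl on that nitrogen; the step from compound 1 to compound 2 concerns the same ring but compares halogens with methoxy, not with hydrogen, so it bears on the present change only loosely. A modest lowering of the number is expected, around a 1.8-fold lower number from compound 3 to compound 4 (0.26 log units; within the scatter), with no change beyond the scatter a real possibility. Compound 4 is expected to give about 1200 nM in this assay, within 500 nM to 3500 nM.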

Compound 4, half-maximal inhibitory concentration: 290 nM
The estimate for compound 4 lay 4.1-fold (0.62 log units) above the measured number; measured number outside the range, below it.
By their numbers in this assay, from the lowest: compound 4; then compound 1; then compound 3; then compound 2.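

In this assay, the change from phenyl to 4-chlorophenyl gives a 7.5-fold lower number from compound 3 to compound 4 (0.87 log units; beyond the scatter) and stays beyond the scatter, with nothing else in the structure altered. For the compounds shown here, the only earlier step on this ring, a 7.5-fold higher number from compound 1 to compound 2 (0.88 log units; beyond the scatter), set one substituted ring against another, whereas this step sets a single chloro against hydrogen on an aromatic carbon, para to a large group, and the lower number lies with the chloro. Nothing at hand accounts for the size of this step.

Whether the lowering is particular to chloro stays open, since the compounds shown do not compare it with a nitrile, a trifluoromethyl or a carboxylic acid at this place. Also open, on these data alone, is whether the same step holds on the core of compound 1.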